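This account rests on a few compounds, and the source may have more. Where it says the series, first, only, none or still open, it means among the compounds named here.

Compound 1 `O=C(Nc1cccc(-n2cc(-c3ccncc3)c(-c3ccc(Cl)c(O)c3)n2)c1)Nc1ccc(Cl)c(Cl)c1`: 1090 nM
Compound 2 `COc1cc(-c2nn(-c3cccc(NC(=O)c4cccc(C(F)(F)F)c4)c3)cc2-c2ccncc2)ccc1Cl`: 1130 nM
Compound 3 `COc1cc(-c2nn(-c3cccc(NC(=O)c4ccccc4)c3)cc2-c2ccncc2)ccc1Cl`: 575 nM

All three were tested in a functional assay on SNB-75 cells (Homo sapiens) for inhibition, read by sulforhodamine B assay, with a stated time of 48 h; a lower number here means a stronger inhibitor of growth, a higher number a weaker inhibitor of growth. Compound 3 gives the lowest of the three numbers, but its gaps to compound 1 and to compound 2 both lie within the scatter, so no one of them can be called the stronger growth inhibitor. Compound 4 `COc1cc(-c2nn(-c3cccc(NC(=O)Nc4ccc(Cl)c(Cl)c4)c3)cc2-c2ccncc2)ccc1Cl` has not yet been measured. It differs from compound 3 in one place: (3,4-dichlorophenyl)amino in place of phenyl on a carbonyl carbon. Within the data shown here, only one measured step between neighbouring compounds is available, a 2.0-fold lower number from compound 2 to compound 3 (0.29 log units; within the scatter), and it concerns a different part of the molecule, so it says little about this change. Compound 1, however, carries the same ((3,4-dichlorophenyl)carbamoyl)amino group as compound 4 while differing from compound 3 elsewhere; compound 1 stands at 1090 nM and compound 3 at 575 nM, a gap within the scatter. Compound 4 is therefore expected to land near 850 nM, within a range from 300 nM to 2400 nM. That estimate means an expected step of a 1.5-fold higher number from compound 3 to compound 4 (0.17 log units; within the scatter), not clearly beyond the scatter.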

Compound 4, concentration for 50% growth inhibition: 1050 nM
Beside the measured number, compound 4's estimate is 1.2-fold (0.09 log units) below it; the range from low to high includes it.
By their numbers in this assay, from the lowest: compounds 3, 4, 1 and 2 (each within the scatter of the next).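

In this assay, replacing phenyl with (3,4-dichlorophenyl)amino on the carbonyl carbon gives a 1.8-fold higher number from compound 3 to compound 4 (0.26 log units; within the scatter) and replacing 3-(trifluoromethyl)phenyl with the same group gives a 1.1-fold lower number from compound 2 to compound 4 (0.03 log units; within the scatter), so this read-out does not separate these three groups at this position. The same holds for the oxygen on the aromatic ring, where methyl in place of hydrogen, alongside other changes to the core, gives a 1.0-fold lower number from compound 1 to compound 4 (0.02 log units; within the scatter). No other data bear on why these numbers lie so close.

Going by these compounds, every group on that carbonyl carbon here carries a six-membered aromatic ring of carbon only, so the outcome with a morpholine or a plain ethyl chain stays open. On these data alone, the contribution of the two chlorines also stays open, since only a comparison with plain phenylamino would separate it from that of the added nitrogen.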